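Cytotoxicity When a Large Side Arm Is Removed

A few compounds are considered here, and "the series" means these few. Any claim that something is new, unique, unknown or untested is made for them only; others in the source may bear on it.

Compound 1, `O=C1O[C@H]([C@@H](O)Cn2cc(CNS(=O)(=O)c3ccc(F)cc3)nn2)C(OCc2ccccc2)=C1OCc1ccccc1`: 30 nM
Compound 2, `O=C1O/C(=C\Cn2cc(-c3ccc(Br)cc3)nn2)C(OCc2ccccc2)=C1OCc1ccccc1`: > 100000 nM
Compound 3, `O=C1O/C(=C\Cn2cc(-c3cc(C(F)(F)F)cc(C(F)(F)F)c3)nn2)C(OCc2ccccc2)=C1OCc1ccccc1`: > 100000 nM

Of the compounds shown here, three sharing the same core have been tested in an ADME assay on HFF cells (Homo sapiens) for cytotoxicity, read by MTT assay, with a stated time of 72 h; a lower number here means a stronger inhibitor, a higher number a weaker inhibitor. In this assay, among the measured compounds shown here, compound 1 gives 30 nM, the only finished number among the three. For compound 2 the result is a limit of the assay, > 100000 nM. For compound 3 the result is likewise a limit, > 100000 nM. So compound 1 stands alone as a measured inhibitor, while the other two sit at the limit of > 100000 nM in this assay, at which 2 of the 3 values shown sit.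

Compound 4, `O=C1O[C@H]([C@@H](O)Cn2ccnn2)C(OCc2ccccc2)=C1OCc1ccccc1`, has not yet been measured in this assay. It differs from compound 1 in one place: hydrogen in place of (((4-fluorophenyl)sulfonyl)amino)methyl on an aromatic carbon. The change strips away the whole (((4-fluorophenyl)sulfonyl)amino)methyl arm and leaves a bare hydrogen on the aromatic carbon. For the measured compounds named here, no measured pair shows this change, so its size can only be guessed. Compound 4 is expected to be a weaker inhibitor than compound 1, with an estimated step of a 100-fold higher number from compound 1 to compound 4 (2.00 log units; beyond the scatter). The estimate for compound 4 is 3000 nM, within a range from 300 nM to 30000 nM.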

Compound 4, half-maximal inhibitory concentration: 610 nM
For compound 4 the middle estimate is 4.9-fold (0.69 log units) above the measured one, within the range that was stated.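

Taking the (((4-fluorophenyl)sulfonyl)amino)methyl arm off the aromatic carbon gives, in this assay, a 20-fold higher number from compound 1 to compound 4 (1.31 log units; beyond the scatter), so this position affects the read-out and the size of the step lies clearly beyond the scatter. The arm therefore contributes to the low number of compound 1, but it is not required for a measurable effect, as compound 4 with only hydrogen at this carbon still gives 610 nM. Compound 4 thus ends in a finished number and not in a limit of the assay: the limit of > 100000 nM in this assay, at which 2 of the 4 values shown sit.

The compounds shown do not reveal which part of the arm carries the step, since nothing stands between the full arm and hydrogen. A plain methyl, an aminomethyl or a directly attached 4-fluorophenyl group at this carbon would leave that question open to test.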